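A few compounds are considered here, and "the series" means these few. Any claim that something is new, unique, unknown or untested is made for them only; others in the source may bear on it.

Working notes on the series. In a functional assay on HepG2 cells (Homo sapiens) for inhibition, read by MTT assay, with a stated time of 48 h (on this read-out higher numbers stand for weaker inhibition and lower numbers for stronger inhibition), compound 1 `Fc1ccc(/C=N/Nc2nc(-c3cccc(Br)c3)cs2)cc1F` gives 16700 nM. Compound 2 `Fc1ccc(/C=N/Nc2nc(-c3ccc(Br)cc3)cs2)cc1F` reaches only a limit of this assay in this assay, namely > 100000 nM. The change between them, (4-bromophenyl in place of 3-bromophenyl on an aromatic carbon), makes the step of an at least 5.9-fold higher number from compound 1 to compound 2 (0.77 log units; beyond the scatter). Compound 3 `COc1cc(/C=N/Nc2nc(-c3cccc(Br)c3)cs2)c(Br)c(Br)c1OC` also reports only a limit in this assay, > 100000 nM. The difference between the core of compound 1 and the core of compound 3 is not broken down here. Compound 4 `COc1cc(/C=N/Nc2nc(-c3ccc(Br)cc3)cs2)c(Br)c(Br)c1OC` is still to be measured in this assay; the change from compound 3 to compound 4 is 4-bromophenyl in place of 3-bromophenyl on an aromatic carbon, the same kind of change as from compound 1 to compound 2. Because compound 3 already sits at the limit of > 100000 nM in this assay, at which 2 of the 3 values shown sit, the step from compound 3 to compound 4 is expected to stay out of reach of a number, estimated as a step that the limit leaves unreadable from compound 3 to compound 4. For compound 4 the expected value is 250000 nM, estimated between 100000 nM and 1000000 nM.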

Compound 4, half-maximal inhibitory concentration: > 100000 nM
Compound 4 gave a limit, no number (the forecaster's own chance of this, stated with the estimate: 90%); the middle value does not contradict the limit.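

No step from compound 3 to compound 4 can be read in this assay, because both compounds give only a limit and no number: the limit of > 100000 nM in this assay, at which 3 of the 4 values shown sit. The compounds shown leave open whether 4-bromophenyl and 3-bromophenyl differ at all on the core of compound 3.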